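The source may hold more compounds than are shown below. What is called first, only, known or untested is meant among the compounds shown, and "the series" means these compounds.

Compound 2 `Cn1cc(SCc2nnc(SCc3cc(Cl)ccc3Cl)n2-c2c(Cl)cccc2Cl)c2ccccc21` was tested in a toxicity assay on HEK-293T cells (Homo sapiens) for cytotoxicity, read by CCK-8 assay, with a stated time of 48 h; a lower number here means that less compound is tolerated, a higher number that more compound is tolerated. In this assay compound 2 reaches only the limit of > 100000 nM, which is a boundary of the test rather than a number. Its close relative compound 1 `Cn1cc(SCc2nnc(SCc3cccc(Cl)c3Cl)n2-c2c(Cl)cccc2Cl)c2ccccc21` likewise gives only the limit of > 100000 nM in this assay. Among the compounds with values here, the single measured step, a step that the two limits leave unreadable from compound 1 to compound 2, therefore cannot be sized, as the limit of > 100000 nM in this assay, at which 2 of the 2 values shown sit, shows. Compound 3 `Cn1cc(SCc2nnc(SCc3cc(Cl)ccc3F)n2-c2c(Cl)cccc2Cl)c2ccccc21` differs from compound 2 by fluoro in place of chloro on an aromatic carbon. Within the data shown here, no measured step covers this exchange of one halogen for another; the only guide is that both measured relatives sit at the limit in this assay. No step beyond the scatter is therefore expected, a number no higher from compound 2 to compound 3 (the limit leaves the size open). Compound 3 is expected to give about 100000 nM in this assay, most likely again reported only as a limit, within a range of 50000 nM to 200000 nM.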

Compound 3, half-maximal cytotoxic concentration: > 100000 nM
Compound 3: only a limit was reported (the forecaster's own chance of this, stated with the estimate: 80%); the middle value sits exactly at the limit.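

No step among compound 1, compound 2 and compound 3 can be read in this assay, because each gives only a limit and no number: the limit of > 100000 nM in this assay, at which 3 of the 3 values shown sit.

The compounds shown leave open how much of each compound the cells tolerate, and whether fluoro in place of chloro changes that at all.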